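Furan-3-yl replacing the hydroxybutenolide on a labdane-type core

This account rests on a few compounds, and the source may have more. Where it says the series, first, only, none or still open, it means among the compounds named here.

Measured so far:
compound 1 `C=C(C)CCC[C@]1(C)C2=CCC[C@](C)(C[C@H](O)C3=CC(=O)OC3O)[C@H]2CC[C@H]1C`, 3800 nM
compound 2 `C=C(C)CCC[C@]1(C)C2=CCC[C@](C)(C[C@@H](O)c3ccoc3)[C@H]2CC[C@H]1C`, 59400 nM
compound 3 `C=C(C)CC[C@]1(C)C2=CCC[C@](C)(C[C@H](O)C3=CC(=O)OC3O)[C@H]2CC[C@H]1C`, 4800 nM

In a functional assay on HeLa cells (Homo sapiens) for antiproliferative activity, read by XTT assay, with a stated time of 72 h (on this read-out lower numbers stand for stronger inhibition and higher numbers for weaker inhibition), compound 1 gives 3800 nM and compound 3 gives 4800 nM. The two cores differ by 1-methylethenyl in place of 2-methylprop-2-en-1-yl on a saturated chain carbon, two bonds along the chain from a saturated ring carbon, and the step of a 1.3-fold higher number from compound 1 to compound 3 (0.10 log units; within the scatter) stays within the scatter. Compound 2 carries a group of 7 heavy atoms (5 carbon, 2 oxygen; one five-membered aromatic ring with 1 hetero atom) in place of a group of 9 heavy atoms (5 carbon, 4 oxygen; one five-membered non-aromatic ring with 1 hetero atom), on a saturated chain carbon bound to a saturated ring carbon, and that change produced a 16-fold higher number from compound 1 to compound 2 (1.19 log units; beyond the scatter). Compound 4 `C=C(C)CC[C@]1(C)C2=CCC[C@](C)(C[C@@H](O)c3ccoc3)[C@H]2CC[C@H]1C` is not yet measured; it carries a group of 7 heavy atoms (5 carbon, 2 oxygen; one five-membered aromatic ring with 1 hetero atom) in place of a group of 9 heavy atoms (5 carbon, 4 oxygen; one five-membered non-aromatic ring with 1 hetero atom), on a saturated chain carbon bound to a saturated ring carbon on the core of compound 3, the same change at the same place as in compound 2. The step of a 16-fold higher number from compound 3 to compound 4 (1.19 log units; beyond the scatter) is expected to be of about the same size as the earlier one, because a 16-fold higher number from compound 1 to compound 2 (1.19 log units; beyond the scatter) was measured on a core that differs from the core of compound 3 only by a change that stayed within the scatter, a 1.3-fold higher number from compound 1 to compound 3 (0.10 log units; within the scatter). Compound 4 is therefore estimated at 75000 nM, expected to fall between 30000 nM and 200000 nM.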

Compound 4, half-maximal inhibitory concentration: 30200 nM
The estimate for compound 4 lay 2.5-fold (0.40 log units) above the measured number; the range from low to high includes it.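

Placing (furan-3-yl)(hydroxy)methyl on the core of compound 3 gives in this assay a 6.3-fold higher number from compound 3 to compound 4 (0.80 log units; beyond the scatter) and the step carries over from the earlier core with no gap beyond the scatter: the same change on two cores in this assay, a 16-fold higher number (1.19 log units; beyond the scatter) from compound 1 to compound 2 and a 6.3-fold higher number (0.80 log units; beyond the scatter) from compound 3 to compound 4, 2.5-fold (0.40 log units) apart, within the scatter of two such steps. The change from 2-methylprop-2-en-1-yl to 1-methylethenyl gives a 2.0-fold lower number from compound 2 to compound 4 (0.29 log units; within the scatter) and also reads alike on both cores: the same change on two cores in this assay, a 1.3-fold higher number (0.10 log units; within the scatter) from compound 1 to compound 3 and a 2.0-fold lower number (0.29 log units; within the scatter) from compound 2 to compound 4, 2.5-fold (0.40 log units) apart, within the scatter of two such steps. These two pairs show transfer only between cores that differ in that one chain, not to cores that differ elsewhere, and they do not show which part of the departing group matters.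

Still open, as far as these compounds go, is how a carboxylic acid or a primary amine at the same place would read in this assay. From the compounds shown here alone, a longer chain in place of 2-methylprop-2-en-1-yl also remains untested by these compounds.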